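Returning the triazole substituent to a carbamoylmethyl chain

The source may hold more compounds than are shown below. What is called first, only, known or untested is meant among the compounds shown, and "the series" means these compounds.

compound 1, `CCOC(=O)C1=Cc2ccccc2OC1(OCc1cn(CC(=O)Nc2ccc(C)cc2)nn1)C(F)(F)F`: > 150000 nM
compound 2, `CCOC(=O)C1=Cc2ccccc2OC1(OCc1cn(-c2ccc(F)c([N+](=O)[O-])c2)nn1)C(F)(F)F`: 16200 nM

Going by the values given here, in a functional assay on MCF7 cells (Homo sapiens) for inhibition, read by MTT assay, with a stated time of 24 h (a higher number here means a weaker inhibitor, a lower number a stronger inhibitor), compound 2 gives 16200 nM, the only numerical value among the two compounds measured so far. For compound 1 the result is a limit of the assay, > 150000 nM. Among the compounds with values here, the sole measured step that bears on the present question is an at least 9.2-fold lower number from compound 1 to compound 2 (0.96 log units; beyond the scatter), supported by the limit of > 150000 nM in this assay, at which 1 of the 2 values shown sits.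

Compound 3, `CCOC(=O)C1=Cc2ccccc2OC1(OCc1cn(CC(=O)Nc2ccc(I)cc2Cl)nn1)C(F)(F)F`, undoes that kind of change: ((2-chloro-4-iodophenyl)carbamoyl)methyl in place of 4-fluoro-3-nitrophenyl on an aromatic nitrogen. The measured step of an at least 9.2-fold lower number from compound 1 to compound 2 (0.96 log units; beyond the scatter) runs opposite to the change now made, so the number for compound 3 is expected to rise by a comparable, at least modest amount in this assay. Compound 3 is therefore expected to give about 100000 nM, within a range of 30000 nM to 300000 nM, with a real chance that only a limit is reported. The expected step is a 6.2-fold higher number from compound 2 to compound 3 (0.79 log units; beyond the scatter).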

Compound 3, half-maximal inhibitory concentration: 28100 nM
Beside the measured number, compound 3's estimate is 3.6-fold (0.55 log units) above it; measured number below the stated range.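

The step back to a carbamoylmethyl chain on this aromatic nitrogen is a 1.7-fold higher number from compound 2 to compound 3 (0.24 log units; within the scatter), so in this assay ((2-chloro-4-iodophenyl)carbamoyl)methyl and 4-fluoro-3-nitrophenyl cannot be told apart. A carbamoylmethyl chain at this position therefore does not by itself go with the weak result of compound 1, and the aryl group on the amide-type nitrogen matters: with 2-chloro-4-iodophenyl in place of 4-methylphenyl, the step is an at least 5.3-fold lower number from compound 1 to compound 3 (0.72 log units; beyond the scatter). That step starts from a limit for compound 1, not a number: the limit of > 150000 nM in this assay, at which 1 of the 3 values shown sits.

The compounds shown do not separate the contribution of the chlorine from that of the iodine. From the compounds shown here alone, how a methoxy group on the same phenyl ring, or a longer chain in place of the carbamoylmethyl, would read also remains open.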